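This account rests on a few compounds, and the source may have more. Where it says the series, first, only, none or still open, it means among the compounds named here.

Working notes on the series.

Compound 1 `COc1cccc(C(=O)N[C@@H](CCC2CCCCC2)C(=O)NCCN2CCc3cc(F)ccc32)c1` gives 2130 nM in an assay on isolated protein for inhibition of cathepsin S (Homo sapiens); on this read-out higher numbers stand for weaker inhibition and lower numbers for stronger inhibition. Compound 2 `COc1cccc(C(=O)N[C@@H](CCC2CCCCC2)C(=O)N[C@H](CN2CCc3cc(F)ccc32)C(C)C)c1` gives 14 nM in this assay, and compound 3 `COc1cccc(C(=O)N[C@@H](CCC2CCCCC2)C(=O)N[C@@H](CC(C)C)CN2CCc3cc(F)ccc32)c1` gives 28 nM. Compound 3 thus stands second highest of the three numbers; its nearest neighbour is compound 2, with a 2.0-fold higher number from compound 2 to compound 3 (0.30 log units; within the scatter), and its furthest is compound 1, with a 76-fold lower number from compound 1 to compound 3 (1.88 log units; beyond the scatter).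

Compound 4 `COc1cccc(C(=O)N[C@@H](CCC2CCCCC2)C(=O)N[C@@H](COCc2ccccc2)CN2CCc3cc(F)ccc32)c1` carries benzyloxy in place of isopropyl on a saturated chain carbon, two bonds along the chain from an amide-type nitrogen. The measured steps that bear on this position are a 150-fold lower number from compound 1 to compound 2 (2.18 log units; beyond the scatter) and a 76-fold lower number from compound 1 to compound 3 (1.88 log units; beyond the scatter), both showing that a substituent on this carbon in place of hydrogen gives a large drop in the number, while a 2.0-fold higher number from compound 2 to compound 3 (0.30 log units; within the scatter) shows that exchanging one such substituent for another of similar kind falls within the scatter. Within the data shown here, no measured step tests a benzyloxy group here. The expected step is therefore small, a 1.3-fold higher number from compound 3 to compound 4 (0.10 log units; within the scatter), with no clear direction beyond the scatter. Compound 4 is estimated at 35 nM in this assay, within a range of 8 nM to 150 nM.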

Compound 4, inhibition constant: 23 nM
Compound 4: the middle estimate sits 1.5-fold (0.18 log units) above what was measured, within the range that was stated.
By their numbers in this assay, from the lowest: compounds 2, 4 and 3 (each within the scatter of the next); then compound 1.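

In this assay benzyloxy, with its 8 heavy atoms, one six-membered aromatic ring and one hydrogen-bond acceptor, can stand in place of isopropyl on this saturated chain carbon with no change beyond the scatter (a 1.2-fold lower number from compound 3 to compound 4 (0.09 log units; within the scatter)), and the same holds for the (benzyloxy)methyl comparison (a 1.6-fold higher number from compound 2 to compound 4 (0.22 log units; within the scatter)). The large difference from the unsubstituted chain carbon of compound 1 therefore persists with a substituent carrying an aromatic ring and an ether oxygen (a 93-fold lower number from compound 1 to compound 4 (1.97 log units; beyond the scatter)), and the isopropyl, isobutyl and (benzyloxy)methyl groups of compounds 2, 3 and 4 are not separated by these numbers. No supporting data at hand explain this outcome.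

Open, on these data alone, is whether an amine or a carboxylic acid on this carbon would keep the number in this range. Also open, as far as these compounds go, is whether an all-carbon chain in place of the ether oxygen, or a longer chain ending in the phenyl ring, would do the same.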